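The source may report more compounds than this note shows. Statements on the series, on what has been measured and on what is new or still open speak of the compounds shown alone.

Measured so far in a functional assay on HT-1080 cells (Homo sapiens) for antiproliferative activity, read by sulforhodamine B assay, with a stated time of 48 h; a higher number here means a weaker inhibitor, a lower number a stronger inhibitor:
- compound 1 `O=C1NCCN1c1ccc(S(=O)(=O)Nc2ccc3[nH]ccc3c2)cc1`: 230 nM
- compound 2 `Cc1cccc(NS(=O)(=O)c2ccc(N3CCNC3=O)cc2)c1`: 210 nM

A lower number here marks a stronger inhibitor, yet compound 1 and compound 2 lie within the usual scatter of repeated measurements, so these two results cannot be told apart. Going by the values given here, compound 2 therefore stands level with the only other measured compound, and that makes it a reasonable reference point for the next comparison.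

The next compound is compound 3 `CCc1cccc(NS(=O)(=O)c2ccc(N3CCNC3=O)cc2)c1`, which differs from compound 2 in a single place: methyl in place of hydrogen on a saturated chain carbon bound to an aromatic carbon. This is methyl in place of hydrogen on a saturated chain carbon bound to an aromatic carbon, so 3-methylphenyl becomes 3-ethylphenyl.

Among the compounds with values here, no measured pair of compounds shows a single-place change, so the data offer no direct guide to the size of this step. For so small an addition, no step beyond the scatter is expected in this assay, in either direction. The expected change is a 1.1-fold lower number from compound 2 to compound 3 (0.02 log units; within the scatter). For compound 3 the estimated value is 200 nM, with an expected range of 80 nM to 500 nM.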

Compound 3, half-maximal inhibitory concentration: 200 nM
Beside the measured number, compound 3's estimate shows no gap at the digits printed; measured number inside the range.
By their numbers in this assay, from the lowest: compounds 3, 2 and 1 (each within the scatter of the next).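

In this assay, the change from 3-methylphenyl to 3-ethylphenyl gives the first direct reading of a single-place change among these compounds: a 1.1-fold lower number from compound 2 to compound 3 (0.02 log units; within the scatter). The earlier compounds shown here could not show this, since compound 1 and compound 2 differ in more than one place; now it is clear that adding one methyl on this saturated chain carbon bound to an aromatic carbon leaves the antiproliferative result indistinguishable from that of compound 2. No independent measurement is available to explain why the result holds steady at this position.

From the compounds shown here alone, a single small step says little about how much room this position offers, so whether a longer chain such as propyl or butyl would also leave the number within the scatter remains open. Also unresolved is how a group of a different kind, such as an amine or a carboxylic acid, would behave in place of the ethyl group on the same core.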